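The source may report more compounds than this note shows. Statements on the series, on what has been measured and on what is new or still open speak of the compounds shown alone.

Measured so far in an ADME assay on microsomes (Mus musculus) for metabolic stability; a lower number here means slower removal, a higher number faster removal of the compound:
compound 1 `COC[C@@H]1CCCN1S(=O)(=O)c1ccc(Cl)c(COc2cccc3c(C(F)(F)F)cc(C)nc23)c1Cl`: 1620 mL/min/kg
compound 2 `Cc1cc(C(F)(F)F)c2cccc(OCc3c(Cl)ccc(S(=O)(=O)N4CC[C@@H](N(C)C)C4)c3Cl)c2n1`: 867 mL/min/kg

Compound 2, at 867 mL/min/kg, lies within the scatter of compound 1, so this assay does not separate the two. The next structure, compound 3 `Cc1cc(C(F)(F)F)c2cccc(OCc3c(Cl)ccc(S(=O)(=O)N4CCCC4)c3Cl)c2n1`, differs from compound 2 in one place: hydrogen in place of dimethylamino on a saturated ring carbon. Hydrogen takes the place of dimethylamino on a saturated ring carbon, which leaves pyrrolidin-1-yl on the sulfonyl sulfur. Going by the values given here, one measured step bears on this, a 1.9-fold lower number from compound 1 to compound 2 (0.27 log units; within the scatter), since it also exchanges the group on the sulfonyl sulfur. Among the compounds with values here, no measured compound carries the unsubstituted pyrrolidin-1-yl, so that step gives no direction, and no change beyond the scatter is expected. The expected step is a 1.4-fold higher number from compound 2 to compound 3 (0.14 log units; within the scatter). For compound 3 the estimated clearance is 1200 mL/min/kg, with an expected range of 600 mL/min/kg to 2400 mL/min/kg.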

Compound 3, clearance: 967 mL/min/kg
Compound 3: middle estimate off by 1.2-fold (0.09 log units), on the high side; the range from low to high includes it.
By their numbers in this assay, from the lowest: compounds 2, 3 and 1 (each within the scatter of the next).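

In this assay, hydrogen in place of dimethylamino on the saturated ring carbon gives a 1.1-fold higher number from compound 2 to compound 3 (0.05 log units; within the scatter), so the pyrrolidin-1-yl group without that substituent is not separated from the substituted one. Hydrogen in place of methoxymethyl gives a 1.7-fold lower number from compound 1 to compound 3 (0.22 log units; within the scatter), so neither substituent on the ring is shown to matter in this read-out when set against the plain ring, and a basic-free comparison adds no direction to the earlier step. No measured evidence bears on why these numbers stay so close.

Still open, going by these compounds, is whether a carboxylic acid, a primary amide or a longer alkyl chain on this ring carbon would move the clearance beyond the scatter. The compounds shown also leave open whether any change away from the sulfonyl sulfur, on the shared core, would do so.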